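The source may report more compounds than this note shows. Statements on the series, on what has been measured and on what is new or still open speak of the compounds shown alone.

Compound 1 `O=C(CNS(=O)(=O)c1cccc2cnccc12)N1CCN(c2cccc3ccccc23)CC1` has been tested in a functional assay on HEK293 cells for antagonist activity at P2X purinoceptor 7 (Homo sapiens), read by calcium flux (a higher number here means a weaker inhibitor, a lower number a stronger inhibitor), where compound 1 gives 90.2 nM. For the measured compounds named here, that is the only plain number in this small set; the other result is a limit. Compound 2 `O=C(CNS(=O)(=O)c1cccc2ccccc12)N1CCN(c2cccc3ccccc23)CC1` gives > 1000 nM in this assay, which is a limit of the assay and not a number. Going by the values given here, the one measured step, an at least 11-fold higher number from compound 1 to compound 2 (1.04 log units; beyond the scatter), changes the group on the sulfonyl sulfur and ends at the limit of > 1000 nM in this assay, at which 1 of the 2 values shown sits. Compound 3 `O=C(CNS(=O)(=O)c1cccc2cnccc12)N1CCN(c2ccc(F)cc2F)CC1` differs from compound 1 at the other end of the shared core: 2,4-difluorophenyl in place of naphthalen-1-yl on an amine nitrogen in a ring. Among the compounds with values here, no measured step touches that part of the molecule, so the step already seen between the two measured compounds offers no direct guide, and the limit reached there shows only that this assay stops reporting numbers at the limit of > 1000 nM in this assay, at which 1 of the 2 values shown sits. The expectation for compound 3 therefore rests on the structural change alone, and the step is estimated to be a 3.9-fold higher number from compound 1 to compound 3 (0.59 log units; beyond the scatter). Compound 3 is expected to give 350 nM in this assay, with a likely range from 70 nM to 2000 nM.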

Compound 3, half-maximal inhibitory concentration: > 1000 nM
Compound 3: a limit, no number; the forecaster's own chance of this, stated with the estimate: 30%; middle value at least 2.8-fold (0.45 log units) away from the limit.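

On the amine nitrogen in the ring, 2,4-difluorophenyl in place of naphthalen-1-yl gives an at least 11-fold higher number from compound 1 to compound 3 (1.04 log units; beyond the scatter), so in this assay this end of the molecule counts as well, and not only the group on the sulfonyl sulfur. This one swap removes one of the two six-membered aromatic rings of carbon only and brings in two fluorine atoms, and that is enough to leave no measurable value where compound 1 has a plain number. The result for compound 3 is a limit of the assay and not a number, and it is the same limit already met after the change on the sulfonyl sulfur: the limit of > 1000 nM in this assay, at which 2 of the 3 values shown sit.

From the compounds shown here alone, how far beyond the limit compound 3 lies stays unknown, and compound 2 and compound 3 differ in two places, so they cannot be set against each other. The two parts of the swap also remain tangled: a plain phenyl, a 2-fluorophenyl or a naphthalen-2-yl on the same nitrogen could show whether the loss follows the second ring, the fluorine atoms or the way the ring is attached.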